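From 4-hydroxypiperidin-1-yl to dimethylamino on a shared core

The source may hold more compounds than are shown below. What is called first, only, known or untested is meant among the compounds shown, and "the series" means these compounds.

In an in vivo ADME assay on the whole organism for metabolic stability, with Canis familiaris (Canis lupus familiaris) as the target (a lower number here means that the compound disappears faster, a higher number that the compound lasts longer), compound 1 (`Nc1noc2ccc(-n3nc(C(F)(F)F)c4c3C(=O)N(c3ccc(-c5ccccc5CN5CCCC5)cc3)CC4)cc12`) gives 5.3 h and compound 2 (`Nc1noc2ccc(-n3nc(C(F)(F)F)c4c3C(=O)N(c3ccc(-c5ccccc5CN5CCC(O)CC5)cc3)CC4)cc12`) gives 6.4 h. Among the compounds with values here, these are the only two numbers so far, and compound 2 stands within the usual scatter of compound 1, so the pair cannot be ranked.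

Compound 3 (`CN(C)Cc1ccccc1-c1ccc(N2CCc3c(C(F)(F)F)nn(-c4ccc5onc(N)c5c4)c3C2=O)cc1`) keeps the core of compound 2 and alters one group: dimethylamino in place of 4-hydroxypiperidin-1-yl on a saturated chain carbon bound to an aromatic carbon. Dimethylamino takes the place of 4-hydroxypiperidin-1-yl on a saturated chain carbon bound to an aromatic carbon.

One measured step alters the same place: a 1.2-fold higher number from compound 1 to compound 2 (0.08 log units; within the scatter). It puts 4-hydroxypiperidin-1-yl in place of pyrrolidin-1-yl and stays within the scatter. Within the data shown here, a single step is thin evidence, and no compound carrying dimethylamino has been measured yet. Taking the value of compound 2, 6.4 h, as the anchor, no change beyond the scatter is expected. The estimated step is a 1.2-fold lower number from compound 2 to compound 3 (0.07 log units; within the scatter). The estimated half-life of compound 3 is 5.5 h, with an expected range of 3.2 h to 9.5 h.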

Compound 3, half-life: 3.8 h
Beside the measured number, compound 3's estimate is 1.4-fold (0.16 log units) above it; low and high end bracket the measured number.
By their numbers in this assay, from the lowest: compounds 3, 1 and 2 (each within the scatter of the next).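

With a third amine on the saturated chain carbon bound to an aromatic carbon, this assay still shows no step beyond the scatter: the change to dimethylamino gives a 1.7-fold lower number from compound 2 to compound 3 (0.23 log units; within the scatter), and the change from the other ring gives a 1.4-fold lower number from compound 1 to compound 3 (0.14 log units; within the scatter). This widens what the first pair showed, since dimethylamino has no ring and only 3 heavy atoms, while 4-hydroxypiperidin-1-yl has a six-membered ring and 7 heavy atoms, yet the half-lives of these compounds cannot be told apart. Nothing measured alongside these numbers offers an explanation of them.

Going by these compounds, all three groups tested at this place are amines joined through their nitrogen, so it remains open whether a different kind of group there, such as a carboxylic acid or a plain hydroxyl, would move the half-life beyond the scatter. On these data alone, it is also open whether a bulkier amine, such as diisopropylamino, or a longer chain ending in an amine would stay within the scatter of these three compounds.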